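The compounds below may be only part of what the source reports. "The series", "measured", "known", "first", "only" and "open" are said of these compounds alone.

Three compounds share one core, an aminothiophene bearing a chlorobenzoyl group and a piperazinylmethyl arm whose far nitrogen carries an aryl group. Compound 1, `Nc1scc(CN2CCN(c3cc(Cl)cc(Cl)c3)CC2)c1C(=O)c1ccc(Cl)cc1`, carries 3,5-dichlorophenyl, and in an assay on CHO cells for displacement of a labelled ligand from adenosine receptor A1 (Homo sapiens), read by scintillation counting, with a stated time of 120 min, tested at 10 uM (a lower number here means less inhibition, a higher number more inhibition at the concentration tested (going by the name of the read-out)), compound 1 gives 1%. Compound 2, `Nc1scc(CN2CCN(c3cccc(C(F)(F)F)c3)CC2)c1C(=O)c1ccc(Cl)cc1`, carries 3-(trifluoromethyl)phenyl, and in this assay compound 2 gives 0%. Compound 3, `Nc1scc(CN2CCN(c3ccccc3F)CC2)c1C(=O)c1ccc(Cl)cc1`, carries 2-fluorophenyl, and in this assay compound 3 gives 4%. The value of compound 3 lies within the scatter of both others: the steps were a number 3 percentage points higher from compound 1 to compound 3 (within the scatter), a number 4 percentage points higher from compound 2 to compound 3 (within the scatter) and a number 1 percentage points lower from compound 1 to compound 2 (within the scatter), so the three aryl groups cannot be told apart on these numbers, and all three compounds sit near the bottom of the inhibition scale.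

Compound 4, `Nc1scc(CN2CCN(c3c(F)cccc3F)CC2)c1C(=O)c1ccc(Cl)cc1`, differs from compound 3 by fluoro in place of hydrogen on an aromatic carbon; cut one bond further out, the change reads 2-fluorophenyl to 2,6-difluorophenyl. For the measured compounds named here, no measured step adds a second fluoro to the 2-fluorophenyl group, but every measured change of the aryl group, whichever substituent entered, stayed within the scatter. A second fluoro is therefore expected to leave the number where it is, with no step beyond the scatter in this assay. Compound 4 is expected to give 3%, estimated within the range 0% to 10%. That estimate means an expected step of a number 1 percentage points lower from compound 3 to compound 4 (within the scatter).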

Compound 4, a percentage reported as inhibition, at one concentration (the size of the read-out at that concentration, not a potency): 1%
For compound 4 the middle estimate is 2 percentage points above the measured one; the measured number falls inside the stated range.
By their numbers in this assay, from the lowest: compounds 2, 1, 4 and 3 (each within the scatter of the next).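

In this assay the change from 2-fluorophenyl to 2,6-difluorophenyl comes to a number 3 percentage points lower from compound 3 to compound 4 (within the scatter) and so adds a new kind of case to the series: here a fluoro enters on an aromatic carbon ortho to a large group and meta to a fluoro group, on an aryl group that keeps its first fluoro, and the number stays within the scatter. Exchanging the other aryl groups for 2,6-difluorophenyl gives a number 1 percentage points higher from compound 2 to compound 4 (within the scatter) and no change at the digits printed from compound 1 to compound 4 (within the scatter), so the four aryl groups cannot be told apart on these numbers and all four compounds remain near the bottom of the inhibition scale. No measurement at hand accounts for these low numbers.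

The compounds shown vary only the aryl group, and only through fluoro, chloro and trifluoromethyl substituents, so it stays open whether an amine or a carboxylic acid on that aryl group would lift the number off the bottom of the scale. On these data alone, it also stays open whether a longer chain in place of the methyl link of the piperazinylmethyl arm, or another group in place of the chlorobenzoyl group, would do so.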